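Notes on an amide series: aryl change ahead of compound 3

A few compounds are considered here, and "the series" means these few. Any claim that something is new, unique, unknown or untested is made for them only; others in the source may bear on it.

Measured so far:
compound 1, `CCCCCCCCNC(=O)[C@@H](NC(=O)c1ccccc1)[C@@H](C)O`, 111000 nM
compound 2, `CCCCCCCCCCCCNC(=O)[C@@H](NC(=O)c1ccccc1)[C@@H](C)O`, 36600 nM

In a functional assay on MCF7 cells (Homo sapiens) for cytotoxicity, read by MTT assay, with a stated time of 48 h (on this read-out lower numbers stand for stronger inhibition and higher numbers for weaker inhibition), compound 1 gives 111000 nM and compound 2 gives 36600 nM, the lower of the two numbers. Among the compounds with values here, the one measured step is a 3.0-fold lower number from compound 1 to compound 2 (0.48 log units; beyond the scatter), a change on the chain only. Compound 3 `CCCCCCCCCCCCNC(=O)[C@@H](NC(=O)c1nccc2ccccc12)[C@@H](C)O` differs from compound 2 by isoquinolin-1-yl in place of phenyl on a carbonyl carbon. Within the data shown here, no measured step touches the group on the carbonyl carbon, so the chain step offers no guide to this change. The expected step is therefore a 1.2-fold lower number from compound 2 to compound 3 (0.09 log units; within the scatter), nothing beyond the scatter. Compound 3 is estimated at 30000 nM, expected to fall between 9000 nM and 100000 nM.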

Compound 3, half-maximal inhibitory concentration: 50500 nM
Beside the measured number, compound 3's estimate is 1.7-fold (0.23 log units) below it; measured number inside the range.
By their numbers in this assay, from the lowest: compounds 2 and 3 (each within the scatter of the next); then compound 1.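

In this assay, within the data shown here, isoquinolin-1-yl in place of phenyl on a carbonyl carbon gives a 1.4-fold higher number from compound 2 to compound 3 (0.14 log units; within the scatter), the only measured step at this position. This position therefore tolerates the larger aromatic group, with its ring nitrogen and hydrogen-bond acceptor, without a change beyond the scatter, unlike the chain step. No supporting data explain this result.

Open, going by these compounds, is whether an amine or a carboxylic acid on the aryl group would move the number beyond the scatter. Also open, on these data alone, is whether isoquinolin-1-yl gives the same result on the shorter chain of compound 1.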